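The compounds below may be only part of what the source reports. "The series", "measured", "known", "first", "only" and "open" are said of these compounds alone.

Of the compounds shown here, three built on one shared core have been measured in an ADME assay on HEK293 cells (Homo sapiens) for cytotoxicity, read by sulforhodamine B assay, with a stated time of 48 h, tested at 10 uM; on this read-out higher numbers stand for more inhibition at the one concentration tested (going by the name of the read-out) and lower numbers for less inhibition. Compound 1 `COc1nc2ccc(Br)cc2cc1C(c1ccccc1)n1cc(-c2ccccc2)nn1` gives 8.25%, and compound 2 `COc1nc2ccc(Br)cc2cc1C(c1ccccc1)n1cc(-c2ccccc2F)nn1` gives 3.97%; between them lies a number 4.3 percentage points lower from compound 1 to compound 2 (within the scatter). Compound 3 `COc1nc2ccc(Br)cc2cc1C(c1ccccc1)n1cc(CCCO)nn1` gives 27.4%, the highest of the three numbers, reached through a number 19.2 percentage points higher from compound 1 to compound 3 (beyond the scatter) and a number 23.4 percentage points higher from compound 2 to compound 3 (beyond the scatter). Compound 4 `COc1nc2ccc(Br)cc2cc1C(c1ccccc1)n1cc(-c2ccc(OC(F)(F)F)cc2)nn1` has not yet been measured. It differs from compound 3 in one place: 4-(trifluoromethoxy)phenyl in place of 3-hydroxypropyl on an aromatic carbon. The measured steps that bear on this are the two in which a 3-hydroxypropyl replaced phenyl or 2-fluorophenyl on that carbon, each a modest rise in this assay. Among the compounds with values here, compound 4 undoes that kind of change, putting an aromatic ring back where compounds 1 and 2 carry one, while the trifluoromethoxy part of the new ring has no counterpart among the measured compounds, so its own contribution is unknown. The step of a number 19.4 percentage points lower from compound 3 to compound 4 (beyond the scatter) is therefore expected, a modest fall. Compound 4 is estimated at 8%, with a range from 0% to 20%.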

Compound 4, a percentage reported as inhibition, at one concentration (the size of the read-out at that concentration, not a potency): 5.8%
Beside the measured number, compound 4's estimate is 2.2 percentage points above it, and the stated range covers the measured number.
By their numbers in this assay, from the lowest: compounds 2, 4 and 1 (each within the scatter of the next); then compound 3.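

In this assay the step to 4-(trifluoromethoxy)phenyl on this aromatic carbon is a number 21.6 percentage points lower from compound 3 to compound 4 (beyond the scatter) and so adds a third aromatic ring to the two that already sit well apart from the 3-hydroxypropyl chain. Adding trifluoromethoxy to the phenyl ring leaves a number 2.5 percentage points lower from compound 1 to compound 4 (within the scatter) as the step, and the change from 2-fluorophenyl gives a number 1.8 percentage points higher from compound 2 to compound 4 (within the scatter) as its step, so these three aromatic groups cannot be told apart in this assay. Nothing available here accounts for the gap between the chain and the aromatic rings.

The compounds shown leave open whether the higher number belongs to the hydroxyl group or to the chain itself, which a plain propyl chain would help to separate. As far as these compounds go, how a longer chain, or an amine or a carboxylic acid at the chain's end, would read at this position also remains unknown.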